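Notes on a lactam-for-triazole exchange in the series

The source may report more compounds than this note shows. Statements on the series, on what has been measured and on what is new or still open speak of the compounds shown alone.

Of the compounds shown here, two of the shared core have been measured in a functional assay on CHO cells for antagonist activity at prostaglandin E2 receptor EP3 subtype (Homo sapiens), read by cAMP accumulation; a higher number here means a weaker inhibitor, a lower number a stronger inhibitor. Among the measured compounds shown here, compound 1 `CC(C)C(c1nnc[nH]1)c1ccc(-c2ccc3cccc(F)c3c2)[nH]c1=O` gives 21 nM in this assay, the lower of the two numbers so far. For the measured compounds named here, compound 2 `CCn1ncc2c(F)cc(-c3ccc(C(CC)(CC)c4ncn(C)n4)c(=O)[nH]3)cc21` gives 96 nM in this assay, a higher number that lies beyond the usual scatter; compound 2 differs from compound 1 in more than one place, so no single step is drawn between them. Compound 3 `CC(C)C(/C=C1\CCNC1=O)c1ccc(-c2ccc3cccc(F)c3c2)[nH]c1=O` has not been measured. It departs from compound 1 as follows: a group of 7 heavy atoms (5 carbon, 1 nitrogen, 1 oxygen; one five-membered non-aromatic ring with 1 hetero atom) in place of a group of 5 heavy atoms (2 carbon, 3 nitrogen; one five-membered aromatic ring with 3 hetero atoms), on a saturated chain carbon bound to an aromatic carbon and a saturated chain carbon Nothing measured in the series covers this exchange, so the expectation rests on compound 1 alone and carries a wide range. The step is expected to be modest and toward a somewhat higher number, about a 1.9-fold higher number from compound 1 to compound 3 (0.28 log units; within the scatter). Compound 3 is therefore expected to give roughly 40 nM in this assay, within 10 nM to 200 nM.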

Compound 3, half-maximal inhibitory concentration: 8.7 nM
Estimate against measurement, compound 3: 4.6-fold (0.66 log units) above, and the stated range ends above it.
By their numbers in this assay, from the lowest: compound 3; then compound 1; then compound 2.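

On the saturated chain carbon bound to an aromatic carbon and a saturated chain carbon, the aromatic 4H-1,2,4-triazol-3-yl group is not needed for activity in this assay on the core of compound 1. Its exchange for the five-membered non-aromatic ring with 1 hetero atom gives a 2.4-fold lower number from compound 1 to compound 3 (0.38 log units; beyond the scatter) and shows that this place accepts a group of 7 heavy atoms with 2 double bonds outside aromatic rings. No measurement at hand accounts for the change, and no part of the entering group can be credited with it.

As far as these compounds go, whether the exchange holds on the core of compound 2 remains open, as the step rests on a single pair. Also open, from the compounds shown here alone, is how a carboxylic acid, an amine or an open-chain amide would compare at this place, and whether the double bond of the entering group is needed.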